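Adding a sulfonyl group to compound 2

This account rests on a few compounds, and the source may have more. Where it says the series, first, only, none or still open, it means among the compounds named here.

In an ADME assay on cells (Hepatocyte, Mus musculus) for cytotoxicity, read by MTT assay, with a stated time of 24 h (a higher number here means that more compound is tolerated, a lower number that less compound is tolerated), compound 2 `FC(F)(F)c1ccc(-c2nn(-c3ccccc3)cc2-c2nc3ccccc3[nH]2)cc1` gives 159000 nM as its reading. Compound 3 `Cc1ccc(C)c(S(=O)(=O)n2c(-c3cn(-c4ccccc4)nc3-c3ccc(F)cc3)nc3ccccc32)c1`, which also carries a sulfonyl group on an aromatic nitrogen, gives 122000 nM and so lies within the scatter of compound 2. Compound 1 `Cc1ccc(-c2nn(-c3ccccc3)cc2-c2nc3ccccc3[nH]2)cc1` gives > 300000 nM as a limit of the assay, not a number. Compound 4 `O=[N+]([O-])c1ccc(S(=O)(=O)n2c(-c3cn(-c4ccccc4)nc3-c3ccc(C(F)(F)F)cc3)nc3ccccc32)cc1` follows from compound 2 with (4-nitrophenyl)sulfonyl in place of hydrogen on an aromatic nitrogen. Going by the values given here, the one measured step, an at least 1.8-fold lower number from compound 1 to compound 2 (0.27 log units; that floor lies within the scatter) in this assay, concerns another place and bears only loosely on this change. Compound 3 at 122000 nM is the closer guide. The expected step is a 1.6-fold lower number from compound 2 to compound 4 (0.20 log units; within the scatter) and it is estimated to be small, towards a lower number. For compound 4 the expected value is 100000 nM with a range from 35000 nM to 250000 nM in this estimate.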

Compound 4, half-maximal cytotoxic concentration: 178000 nM
The estimate for compound 4 lay 1.8-fold (0.25 log units) below the measured number; the range from low to high includes it.
By their numbers in this assay, from the lowest: compounds 3, 2 and 4 (each within the scatter of the next). At a limit, above all of these: compound 1.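

In this assay the exchange of hydrogen for (4-nitrophenyl)sulfonyl on the aromatic nitrogen gives a 1.1-fold higher number from compound 2 to compound 4 (0.05 log units; within the scatter), so this position takes a group of 12 heavy atoms with no change beyond the scatter. Going by these compounds alone, compound 3 also carries a sulfonyl group there, but it differs elsewhere too, so only this step reads the change alone. As far as these compounds go, whether an amine or a carboxylic acid in place of the nitro group would read the same stays open. Compound 1 remains a limit and not a number: the limit of > 300000 nM in this assay, at which 1 of the 4 values shown sits.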